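Changing the aryl group of compound 1

The compounds below may be only part of what the source reports. "The series", "measured", "known", "first", "only" and "open" are said of these compounds alone.

Among the measured compounds shown here, compound 1 (`COC(=O)N1N=C(c2ccc(OC)cc2)CC1c1cc(OC)c(OC)c(OC)c1`) gives 1710 nM in a functional assay on HepG2 cells (Homo sapiens) for antiproliferative activity, read by MTT assay, with a stated time of 48 h (a higher number here means a weaker inhibitor of growth, a lower number a stronger inhibitor of growth), and holds the lower of the two numbers so far. Compound 2 (`CCOC(=O)N1N=C(c2ccc(OC)cc2)CC1c1cc(OC)c(OC)c(OC)c1`) gives 9400 nM there. For the measured compounds named here, the one measured step, a 5.5-fold higher number from compound 1 to compound 2 (0.74 log units; beyond the scatter) and beyond the scatter, is methyl in place of hydrogen on a saturated chain carbon bound to an oxygen next to a carbonyl group. Compound 3 (`COC(=O)N1N=C(c2cccc(Cl)c2)CC1c1cc(OC)c(OC)c(OC)c1`) instead has 3-chlorophenyl in place of 4-methoxyphenyl on a carbon with a double bond to nitrogen and otherwise matches compound 1. Going by the values given here, no measured step touches this place, so the data show no direction and give only a rough idea of size. A modest rise in this assay is a cautious guess, and the estimated step is a 1.8-fold higher number from compound 1 to compound 3 (0.24 log units; within the scatter) at the middle of the range. For compound 3 the expected value is 3000 nM within an estimated range from 900 nM to 11000 nM overall.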

Compound 3, concentration for 50% growth inhibition: 1240 nM
The estimate for compound 3 lay 2.4-fold (0.38 log units) above the measured number, within the range that was stated.
By their numbers in this assay, from the lowest: compounds 3 and 1 (each within the scatter of the next); then compound 2.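

Putting 3-chlorophenyl in place of 4-methoxyphenyl on the carbon with a double bond to nitrogen gives a 1.4-fold lower number from compound 1 to compound 3 (0.14 log units; within the scatter) in this assay. This position therefore tolerates this exchange with no readable change, even though the entering group has no hydrogen-bond acceptor and the leaving group has one. Among the compounds shown here, the step at the ester end of the molecule, a 5.5-fold higher number from compound 1 to compound 2 (0.74 log units; beyond the scatter), remains the only change so far that moves the number beyond the scatter, and no supporting measurement bears on why the aryl swap leaves the number in place. This single swap alters both the substituent and where it sits on the phenyl ring, so those two changes cannot be told apart. On these data alone, whether an amine or a carboxylic acid on that phenyl ring would keep the number also remains open.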